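Swapping the 4-methoxyphenyl group for a basic-free chain label

The source may report more compounds than this note shows. Statements on the series, on what has been measured and on what is new or still open speak of the compounds shown alone.

Of the compounds shown here, two have been measured so far in a functional assay (B cells) with Mus musculus as the target (a lower number here means that less compound is needed, a higher number that more compound is needed for the effect), so far.

- compound 1 `Nc1nc(O)c2c(n1)n(C1OC(CO)[C@@H](O)[C@H]1O)c(=O)n2C/C=C/c1ccccc1` gives 103 uM
- compound 2 `COc1ccc(Cn2c(=O)n(C3OC(CO)[C@@H](O)[C@H]3O)c3nc(N)nc(O)c32)cc1` gives 135 uM

Compound 2 lies within the scatter of compound 1. Compound 3 `CN(C)CCCn1c(=O)n(C2OC(CO)[C@@H](O)[C@H]2O)c2nc(N)nc(O)c21` is next, and the change is 2-(dimethylamino)ethyl in place of 4-methoxyphenyl on a saturated chain carbon bound to an aromatic nitrogen, with 2-(dimethylamino)ethyl in place of 4-methoxyphenyl on a saturated chain carbon bound to an aromatic nitrogen. Going by the values given here, the only measured step at this place, a 1.3-fold higher number from compound 1 to compound 2 (0.12 log units; within the scatter), exchanged one ring-bearing group for another. Among the compounds with values here, no measured compound has a group without a ring here, so the guide is weak. Expected in this assay is a 1.1-fold higher number from compound 2 to compound 3 (0.05 log units; within the scatter), nothing beyond the scatter, though with wide uncertainty. For compound 3 the estimated value is 150 uM, with an expected range from 50 uM to 450 uM.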

Compound 3, concentration for half-maximal effect: 194 uM
For compound 3 the middle estimate is 1.3-fold (0.11 log units) below the measured one; the range from low to high includes it.
By their numbers in this assay, from the lowest: compounds 1, 2 and 3 (each within the scatter of the next).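

In this assay, a group without a ring is now tested on a saturated chain carbon bound to an aromatic nitrogen: a 1.4-fold higher number from compound 2 to compound 3 (0.16 log units; within the scatter) and a 1.9-fold higher number from compound 1 to compound 3 (0.27 log units; within the scatter), both within the scatter. Across these compounds, 2-(dimethylamino)ethyl is therefore not separated from the ring-bearing 4-methoxyphenyl or 2-phenylethenyl, so a ring at this place is not shown to be needed. No evidence on the cause is available.

From the compounds shown here alone, whether a carboxylic acid, a primary amine or a longer chain here would give a step beyond the scatter remains open.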